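A few compounds are considered here, and "the series" means these few. Any claim that something is new, unique, unknown or untested is made for them only; others in the source may bear on it.

Of the compounds shown here, three that share one core have been tested in a functional assay on ECV-304 cells (Homo sapiens); on this read-out higher numbers stand for an effect only at larger amounts of compound and lower numbers for an effect already at smaller amounts. Compound 1 `Cc1nc(C)c(CN2CCNCC2)nc1C` carries a free ring amine and gives 481000 nM. Compound 2 `Cc1nc(C)c(CN2CCN(C/C=C/c3ccccc3)CC2)nc1C`, which bears a larger group on that ring nitrogen, gives 428000 nM, and compound 3 `Cc1nc(C)c(CN2CCN(N3CCN(Cc4nc(C)c(C)nc4C)CC3)CC2)nc1C` gives 311000 nM. All three numbers lie within the usual scatter of one another, so compound 1 does not stand apart from the other two in this assay.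

Compound 4 `Cc1nc(C)c(CN2CCN(c3ccccc3)CC2)nc1C` has not yet been measured. It differs from compound 1 in one place: phenyl in place of hydrogen on an amine nitrogen in a ring. Among the compounds with values here, no measured pair shows exactly this change. Compound 2, with another large group on the same nitrogen, gives 428000 nM and sits within the scatter of compound 1, so no step beyond the scatter is expected in either direction. The step from compound 1 to compound 4 in this assay is estimated as a 1.2-fold lower number from compound 1 to compound 4 (0.08 log units; within the scatter). Compound 4 is therefore expected to give about 400000 nM, with a likely range from 150000 nM to 1000000 nM.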

Compound 4, half-maximal effective concentration: 665000 nM
Beside the measured number, compound 4's estimate is 1.7-fold (0.22 log units) below it, and the stated range covers the measured number.
By their numbers in this assay, from the lowest: compounds 3, 2, 1 and 4 (each within the scatter of the next, the first and the last beyond it).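

In this assay, phenyl in place of hydrogen on the amine nitrogen in a ring gives a 1.4-fold higher number from compound 1 to compound 4 (0.14 log units; within the scatter). Within the data shown here, this is the first step at this position that can be read as a single change, since the earlier compounds offered no pair differing in one place only. It shows that adding one six-membered aromatic ring of carbon at this nitrogen leaves the number within the usual scatter of repeated measurements, with no clear gain or loss, and nothing available here accounts for the size of the step.

Still open, as far as these compounds go, is whether a small group such as methyl, or a chain ending in an amine or a carboxylic acid, on the same nitrogen would give a step beyond the scatter. Also open, from the compounds shown here alone, is whether any change at this position would bring an effect at much smaller amounts of compound.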